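Dropping one methoxy group from compound 2

This account rests on a few compounds, and the source may have more. Where it says the series, first, only, none or still open, it means among the compounds named here.

Three compounds have been measured in a functional assay on 786-0 cells (Homo sapiens) for inhibition, read by sulforhodamine B assay, with a stated time of 48 h; a higher number here means a weaker inhibitor of growth, a lower number a stronger inhibitor of growth:
compound 1 `COc1ccc(-c2[nH]c3ccccc3c2/C=C(\C#N)S(=O)(=O)c2ccccc2)cc1`, 1200 nM
compound 2 `COc1ccc(-c2[nH]c3ccc(OC)cc3c2/C=C(\C#N)S(=O)(=O)c2ccccc2)cc1`, 2100 nM
compound 3 `CC(=O)/C(=C\c1c(-c2ccccc2)[nH]c2ccccc12)S(=O)(=O)c1ccccc1`, 1600 nM

The number for compound 2 lies within the scatter of both compound 1 and compound 3, so no ranking among the three is supported. Within the data shown here, the only single-point step measured, a 1.8-fold higher number from compound 1 to compound 2 (0.24 log units; within the scatter), adds a methoxy and stays within the scatter. Compound 4 `COc1ccc2[nH]c(-c3ccccc3)c(/C=C(\C#N)S(=O)(=O)c3ccccc3)c2c1` differs from compound 2 by hydrogen in place of methoxy on an aromatic carbon. Among the measured compounds shown here, no measured step removes this particular methoxy, and compound 3 differs from compound 1 in two places, so its value cannot be read as one step. Compound 4 is therefore expected to show a 1.1-fold lower number from compound 2 to compound 4 (0.04 log units; within the scatter) in this assay, no change beyond the scatter. Compound 4 is estimated at 1900 nM, in the range 800 nM to 4500 nM.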

Compound 4, concentration for 50% growth inhibition: 6100 nM
The estimate for compound 4 lay 3.2-fold (0.51 log units) below the measured number; measured number outside the range, above it.
By their numbers in this assay, from the lowest: compounds 1, 3 and 2 (each within the scatter of the next); then compound 4.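

Going from 4-methoxyphenyl to phenyl in this assay gives a 2.9-fold higher number from compound 2 to compound 4 (0.46 log units; beyond the scatter), so the methoxy at this place counts for growth inhibition in this series. The other methoxy, in a 1.8-fold higher number from compound 1 to compound 2 (0.24 log units; within the scatter), stayed within the scatter, so the two methoxy groups do not behave alike here. Nothing available accounts for this loss.

The compounds shown leave open whether a hydroxyl, an amine or an ethoxy group at this place would match the methoxy. They also leave open whether the same change would cost as much without the second methoxy on the shared core.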